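The compounds below may be only part of what the source reports. "The series", "measured", "known", "first", "only" and "open" are said of these compounds alone.

Compound 1 `CC(C)OC(=O)NCCS(=O)(=O)NC(=O)c1ccc(Nc2nc(NC3(c4ccc(Cl)cc4)CC3)nc(OCC(F)(F)F)n2)cc1` was tested in a physicochemical assay for permeability, using PAMPA, at pH 7.4 (on this read-out higher numbers stand for higher permeability and lower numbers for lower permeability), where compound 1 gives 71 nm/s, the lowest of the three numbers in hand. Compound 2 `O=C(NS(=O)(=O)c1ccccc1)c1ccc(Nc2nc(NC3(c4ccc(Cl)cc4)CC3)nc(OCC(F)(F)F)n2)cc1` gives 182 nm/s and compound 3 `Cc1ccccc1S(=O)(=O)NC(=O)c1ccc(Nc2nc(NC3(c4ccc(Cl)cc4)CC3)nc(OCC(F)(F)F)n2)cc1` gives 265 nm/s; the changes were a 2.6-fold higher number from compound 1 to compound 2 (0.41 log units; beyond the scatter) and a 3.7-fold higher number from compound 1 to compound 3 (0.57 log units; beyond the scatter), while a 1.5-fold higher number from compound 2 to compound 3 (0.16 log units; within the scatter). Compound 4 `CC(C)S(=O)(=O)NC(=O)c1ccc(Nc2nc(NC3(c4ccc(Cl)cc4)CC3)nc(OCC(F)(F)F)n2)cc1` differs from compound 1 at the same sulfonyl sulfur: isopropyl in place of 2-((isopropoxycarbonyl)amino)ethyl on a sulfonyl sulfur. The two steps from compound 1 that bear on this replace the same 2-((isopropoxycarbonyl)amino)ethyl group and both rose beyond the scatter, so a modest rise is expected here too, a 2.5-fold higher number from compound 1 to compound 4 (0.40 log units; beyond the scatter). Compound 4 is therefore estimated at 180 nm/s, within a range of 90 nm/s to 360 nm/s.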

Compound 4, apparent permeability: 31 nm/s
Compound 4: the middle estimate sits 5.8-fold (0.76 log units) above what was measured; the measured number lies below the stated range.
By their numbers in this assay, from the lowest: compound 4; then compound 1; then compounds 2 and 3 (each within the scatter of the next).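

Replacing the 2-((isopropoxycarbonyl)amino)ethyl group on the sulfonyl sulfur does not always raise the number in this assay: isopropyl gives a 2.3-fold lower number from compound 1 to compound 4 (0.36 log units; beyond the scatter), so the direction of the change depends on the entering group. Isopropyl also falls clearly short of the two aromatic groups, with a 5.9-fold lower number from compound 2 to compound 4 (0.77 log units; beyond the scatter) and an 8.5-fold lower number from compound 3 to compound 4 (0.93 log units; beyond the scatter). No measurement here explains this reversal. The compounds shown leave open whether the aromatic ring itself separates these groups, or whether a cyclohexyl ring or a longer alkyl chain on the same sulfur would behave like phenyl or like isopropyl.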